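The source may hold more compounds than are shown below. What is called first, only, known or untested is meant among the compounds shown, and "the series" means these compounds.

Measured so far: compound 1 `COc1ccc(CNc2ccc(C3CCCCC3)cc2)c(O)c1`, "not active" (no number reported); compound 2 `Oc1ccccc1CNc1ccc(-c2ccccc2)nc1`, 840 nM.

For the measured compounds named here, compound 2 holds the only number on a functional assay on Jurkat cells (Homo sapiens) for activation, with a stated time of 24 h; on this read-out higher numbers stand for an effect only at larger amounts of compound and lower numbers for an effect already at smaller amounts; compound 1 carries no number in this assay and stands as not active. Compound 3 `CCSc1ccc(-c2ccc(NCc3ccccc3O)cn2)cc1` differs from compound 2 by ethylsulfanyl in place of hydrogen on an aromatic carbon. Going by the values given here, no step between measured compounds is available to scale this change, so the expectation rests on compound 2 alone. A small gain in potency is expected, with a 1.7-fold lower number from compound 2 to compound 3 (0.23 log units; within the scatter) at the edge of the scatter. Compound 3 is thus expected at 500 nM, between 150 nM and 2000 nM.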

Compound 3, half-maximal effective concentration: 1920 nM
Compound 3: the middle estimate sits 3.8-fold (0.58 log units) below what was measured; the range from low to high includes it.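

At this position, on an aromatic carbon para to a large group, ethylsulfanyl keeps a measurable number in this assay but does not lower it, the step being a 2.3-fold higher number from compound 2 to compound 3 (0.36 log units; beyond the scatter). Hydrogen therefore compares favourably with this one sulfur-linked chain here, though a single step gives no trend. For the compounds shown here, nothing measured so far accounts for this loss.

Open, on these data alone, is whether fluorine, an amine or a carboxylic acid at this position would match compound 2. A longer chain on the sulfur is equally unresolved.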